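A Second Fluorine on a Bisaryl Indole Acetyl Scaffold

A few compounds are considered here, and "the series" means these few. Any claim that something is new, unique, unknown or untested is made for them only; others in the source may bear on it.

Of the compounds shown here, three that share one core have been measured in a functional assay on HeLa cells (Homo sapiens) for cytotoxicity, read by MTT assay, with a stated time of 2 days, tested at 0.1 uM; a lower number here means a stronger effect, a higher number a weaker effect of the compound at the concentration tested. Compound 1 `CC(=O)c1cc(-c2ccccc2)cc2cc(-c3ccccc3)[nH]c12` gives 72.3%. Compound 2 `CC(=O)c1cc(-c2ccc(F)cc2)cc2cc(-c3ccccc3)[nH]c12` gives 90.3%, and compound 3 `CC(=O)c1cc(-c2ccccc2)cc2cc(-c3ccc(F)cc3)[nH]c12` gives 91.1%. Compound 3 thus holds the highest of the three numbers, standing within the scatter of compound 2 and beyond it only against compound 1.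

Compound 4 `CC(=O)c1cc(-c2ccc(F)cc2)cc2cc(-c3ccc(F)cc3)[nH]c12` differs from compound 3 by fluoro in place of hydrogen on an aromatic carbon, placed on an aromatic carbon of a six-membered aromatic ring of carbon only, para to a large group. Within the data shown here, two measured steps bear on this: a number 18 percentage points higher from compound 1 to compound 2 (beyond the scatter) and a number 18.8 percentage points higher from compound 1 to compound 3 (beyond the scatter). Both fluoro additions raised the number by a modest amount, yet compound 3 already lies close to the top of the percentage scale, so little room remains. The step is therefore expected to be small and upward, at most at the edge of the scatter, and compound 4 is estimated at 95%, within 85% to 103%, which means an expected step of a number 3.9 percentage points higher from compound 3 to compound 4 (within the scatter).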

Compound 4, a percentage reported as activity, at one concentration (the size of the read-out at that concentration, not a potency): 90.1%
Compound 4: the middle estimate sits 4.9 percentage points above what was measured; low and high end bracket the measured number.
By their numbers in this assay, from the lowest: compound 1; then compounds 4, 2 and 3 (each within the scatter of the next).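

The second fluoro behaves unlike the first: the change from phenyl to 4-fluorophenyl, which moved the number on compound 1, gives a number 1 percentage points lower from compound 3 to compound 4 (within the scatter) and a number 0.2 percentage points lower from compound 2 to compound 4 (within the scatter) in this assay. The effect of this change therefore depends on whether the core already carries a fluoro, as the first pair of steps shows: the same change on two cores in this assay, a number 18 percentage points higher (beyond the scatter) from compound 1 to compound 2 and a number 1 percentage points lower (within the scatter) from compound 3 to compound 4, 19 percentage points apart, beyond the scatter of two such steps The second pair, with the change made on the other aryl group, shows the same: the same change on two cores in this assay, a number 18.8 percentage points higher (beyond the scatter) from compound 1 to compound 3 and a number 0.2 percentage points lower (within the scatter) from compound 2 to compound 4, 19 percentage points apart, beyond the scatter of two such steps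

From the compounds shown here alone, it remains open whether a chloro or methoxy group, or an amine, in place of this fluoro would also leave the number flat on a core already bearing one fluoro. Each reading also comes from a single concentration, so it shows only how strong or weak the effect of these compounds is at that concentration.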